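The source may report more compounds than this note shows. Statements on the series, on what has been measured and on what is new or still open speak of the compounds shown alone.

Compound 1 `COc1ccc2c(c1)c(/C=N/O)cn2Cc1cn([C@@H]2O[C@H](COC(C)=O)[C@@H](OC(C)=O)[C@H](OC(C)=O)[C@H]2OC(C)=O)nn1` is one of three compounds tested in an ADME assay on NIH3T3 cells (Homo sapiens) for cytotoxicity, read by sulforhodamine B assay, with a stated time of 48 h; on this read-out higher numbers stand for weaker inhibition and lower numbers for stronger inhibition. In this assay compound 1 gives 26200 nM, the highest of the two plain numbers shown. The nearest is compound 2 `CC(=O)OC[C@H]1O[C@@H](n2cc(Cn3cc([N+](=O)[O-])c4ccccc43)nn2)[C@H](OC(C)=O)[C@@H](OC(C)=O)[C@@H]1OC(C)=O`, which in this assay gives 20500 nM, within the scatter of compound 1. Compound 3 `CC(=O)OC[C@H]1O[C@@H](n2cc(Cn3cc(/C=C4/C(=O)Nc5ccccc54)c4ccccc43)nn2)[C@H](OC(C)=O)[C@@H](OC(C)=O)[C@@H]1OC(C)=O` gives no number in this assay but only a limit, > 200000 nM. For the measured compounds named here, the single step with a paired structure, an at least 9.7-fold higher number from compound 2 to compound 3 (0.98 log units; beyond the scatter), replaces a small group on the shared core with a far larger ring-bearing group, and its size is set by a limit (the limit of > 200000 nM in this assay, at which 1 of the 3 values shown sits).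

Compound 4 `COc1ccc2c(c1)c(/C=C1/C(=O)Nc3ccc(F)cc31)cn2Cc1cn([C@@H]2O[C@H](COC(C)=O)[C@@H](OC(C)=O)[C@H](OC(C)=O)[C@H]2OC(C)=O)nn1` differs from compound 1 in a closely related way: a group of 12 heavy atoms (9 carbon, 1 nitrogen, 1 oxygen, 1 fluorine; one five-membered non-aromatic ring with 1 hetero atom, one six-membered aromatic ring of carbon only) in place of a group of 3 heavy atoms (1 carbon, 1 nitrogen, 1 oxygen; no ring), on an aromatic carbon. The entering group matches the one that enters in the measured step, with one fluorine added, so a step towards a higher number in this assay is expected, probably large. The estimate for compound 4 is therefore 200000 nM, in the range 60000 nM to 700000 nM, a step of a 7.6-fold higher number from compound 1 to compound 4 (0.88 log units; beyond the scatter), with a real chance that this assay again reports only a limit.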

Compound 4, half-maximal inhibitory concentration: > 200000 nM
Compound 4: no number, only a limit; the forecaster's own chance of this, stated with the estimate: 60%; the middle value sits exactly at the limit.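

The rise seen for the earlier pair returns on the core of compound 1. In this assay the change is an at least 7.6-fold higher number from compound 1 to compound 4 (0.88 log units; beyond the scatter), so swapping a small group without a ring for the larger group with two rings, on this aromatic carbon of the five-membered aromatic ring, raises the number on a second pair, and the group that leaves is a different one. Compound 4 gives only a limit and not a number, so the step gives a minimum and its full size stays unknown: the limit of > 200000 nM in this assay, at which 2 of the 4 values shown sit.

The compounds shown do not separate the part played by the fluorine from that of the rest of the entering group. They also leave open what a group of intermediate size at this place, such as a carboxylic acid or an amine on a short chain, would give.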